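The source may hold more compounds than are shown below. What is called first, only, known or untested is meant among the compounds shown, and "the series" means these compounds.

In an assay on isolated protein for displacement of a labelled ligand from 5-hydroxytryptamine receptor 6 (Homo sapiens) (on this read-out lower numbers stand for stronger inhibition and higher numbers for weaker inhibition), compound 3 `O=C(NC[C@@H]1CCCc2cc(S(=O)(=O)c3cccc(F)c3)ccc21)c1ccc[nH]1` gives 5.01 nM. Compound 2 `NC[C@@H]1CCCc2cc(S(=O)(=O)c3cc(F)cc4[nH]cnc34)ccc21` gives 5.01 nM in this assay, which sits level with compound 3 within the usual scatter, and together these two are the highest numbers among the three measured compounds. Compound 1 `NC[C@@H]1CCCc2cc(S(=O)(=O)c3c[nH]c4ccccc34)ccc21` gives 0.0501 nM in this assay, a far lower number than either of the other two. Compound 4 `CC(=O)N(C)C[C@@H]1CCCc2cc(S(=O)(=O)c3cccc(F)c3)ccc21` has not yet been measured. The change from compound 3 to compound 4 is acetyl(methyl)amino in place of ((1H-pyrrol-2-yl)carbonyl)amino on a saturated chain carbon bound to a saturated ring carbon. Within the data shown here, no measured pair shows a change of this kind, so the size of the step rests on judgement alone. The expectation is that a 10-fold higher number from compound 3 to compound 4 (1.00 log units; beyond the scatter) runs toward a higher number, a moderate step that lies beyond the scatter. For compound 4 in this assay the estimate is 50 nM, with a likely range from 8 nM to 300 nM.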

Compound 4, inhibition constant: 1.59 nM
Compound 4: the middle estimate sits 31-fold (1.50 log units) above what was measured, and the stated range ends above it.
By their numbers in this assay, from the lowest: compound 1; then compound 4; then compounds 2 and 3 (each within the scatter of the next).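

In this assay, acetyl(methyl)amino in place of ((1H-pyrrol-2-yl)carbonyl)amino gives a 3.2-fold lower number from compound 3 to compound 4 (0.50 log units; beyond the scatter). At this place, on a saturated chain carbon bound to a saturated ring carbon, neither the five-membered aromatic ring nor any hydrogen-bond donor is needed for a low number, at least in this pair. Nothing measured here accounts for the step.

The change removes the ring and adds the methyl on nitrogen together, so the share of each cannot be told apart. Going by these compounds, how plain acetylamino, or a longer chain such as propanoyl(methyl)amino, would read in this assay remains open.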